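From methoxy to fluoro on a shared core

The compounds below may be only part of what the source reports. "The series", "measured", "known", "first", "only" and "open" are said of these compounds alone.

Values in a functional assay on CWR22R cells (Homo sapiens) for inhibition, read by MTT assay, with a stated time of 48 h (on this read-out higher numbers stand for weaker inhibition and lower numbers for stronger inhibition), are these:
compound 1 `COc1ccc2c(C3CC(c4ccncc4)=NO3)c[nH]c2c1` gives 16300 nM
compound 2 `COc1ccc2[nH]cc(C3CC(c4ccncc4)=NO3)c2c1` gives 35500 nM
compound 3 `COc1ccc2c(C3CC(c4ccncc4)=NO3)cn(Cc3ccc(Cl)cc3)c2c1` gives 17300 nM

Compound 1 and compound 3 lie within the scatter of each other, while compound 2 gives a higher number than compound 1 by slightly more than the scatter. Compound 4 `Fc1ccc2c(C3CC(c4ccncc4)=NO3)c[nH]c2c1` has not yet been measured. It departs from compound 1 by fluoro in place of methoxy on an aromatic carbon with fluoro in place of methoxy on an aromatic carbon. For the measured compounds named here, the one measured step is a 1.1-fold higher number from compound 1 to compound 3 (0.03 log units; within the scatter) and it puts 4-chlorobenzyl in place of hydrogen on an aromatic nitrogen, so it bears on this change only loosely. Compound 2 carries its methoxy on a different aromatic carbon and gives 35500 nM which is the closest hint available, and a small one. Going by the values given here, no fluoro compound has been measured, so no clear direction can be drawn and no shift beyond the scatter is expected. The estimated step is a 1.2-fold higher number from compound 1 to compound 4 (0.09 log units; within the scatter) in this assay and it remains uncertain. For compound 4 the expected value is 20000 nM within an estimated range from 8000 nM to 50000 nM.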

Compound 4, half-maximal inhibitory concentration: 3660 nM
Estimate against measurement, compound 4: 5.5-fold (0.74 log units) above; the measured number lies below the stated range.
By their numbers in this assay, from the lowest: compound 4; then compounds 1 and 3 (each within the scatter of the next); then compound 2.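

Replacing methoxy with fluoro on this aromatic carbon gives, in this assay, a 4.5-fold lower number from compound 1 to compound 4 (0.65 log units; beyond the scatter) and thus stronger inhibition, so this position on the shared core responds to the group it carries. The earlier change on the aromatic nitrogen, a 1.1-fold higher number from compound 1 to compound 3 (0.03 log units; within the scatter), stayed within the scatter, which leaves the fluoro step as the only listed single change here that goes beyond it. Nothing available explains why this exchange lowers the number.

The compounds shown leave open whether the step reflects fluoro itself or the departure of methoxy, and how chloro, an amine or a plain hydrogen on this carbon would compare. They also leave open whether fluoro and 4-chlorobenzyl together would behave as fluoro does alone.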